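The source may report more compounds than this note shows. Statements on the series, on what has been measured and on what is new or still open speak of the compounds shown alone.

Of the compounds shown here, two have been measured in an ADME assay on Vero cells (Chlorocebus sabaeus) for cytotoxicity, read by MTT assay, with a stated time of 72 h; a lower number here means a stronger inhibitor, a higher number a weaker inhibitor. Compound 1 `O=[N+]([O-])c1c[nH]c(-c2nnc(-c3cc(-c4ccccc4)nc4ccc(Cl)cc34)o2)c1` gives 281000 nM in this assay, and compound 2 `O=[N+]([O-])c1c[nH]c(-c2nnc(-c3ccc[nH]3)o2)c1` gives 227000 nM. Compound 2 stands lowest of the two numbers, yet its nearest neighbour, compound 1, lies within the scatter, so the pair cannot be told apart. Compound 3 `O=[N+]([O-])c1c[nH]c(-c2nnc(-c3cccs3)o2)c1` differs from compound 2 by thiophen-2-yl in place of 1H-pyrrol-2-yl on an aromatic carbon. Within the data shown here, no measured pair shows this change, so the expected step, a 1.1-fold higher number from compound 2 to compound 3 (0.02 log units; within the scatter), is none beyond the scatter in this assay. Compound 3 is therefore estimated at 240000 nM, within a range from 100000 nM to 600000 nM.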

Compound 3, half-maximal inhibitory concentration: 418000 nM
Beside the measured number, compound 3's estimate is 1.7-fold (0.24 log units) below it; measured number inside the range.
By their numbers in this assay, from the lowest: compounds 2, 1 and 3 (each within the scatter of the next).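

In this assay, among these compounds, thiophen-2-yl in place of 1H-pyrrol-2-yl on an aromatic carbon gives a 1.8-fold higher number from compound 2 to compound 3 (0.27 log units; within the scatter), the first reading of this change at this position. Between these two compounds, exchanging the ring nitrogen and its hydrogen-bond donor for a ring sulfur therefore leaves a difference that cannot be told from the scatter. Nothing at hand speaks to why the two compounds read alike. Still open, on these data alone, is whether an amine, a carboxylic acid or a longer chain on this same aromatic carbon would give a step beyond the scatter.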